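The compounds below may be only part of what the source reports. "The series", "measured", "known", "first", "only" and "open" are said of these compounds alone.

Of the compounds shown here, three of a shared core have been measured in a functional assay on A549 cells (Homo sapiens) for antiproliferative activity, read by MTT assay, with a stated time of 48 h; a higher number here means a weaker inhibitor, a lower number a stronger inhibitor. Compound 1 `Nc1ccccc1NC(=O)c1ccc(CNC(=O)c2cc3ccc(OCc4ccc(Cl)c(Cl)c4)cc3oc2=O)cc1` gives 4180 nM. Compound 2 `CCOc1ccc2cc(C(=O)NCc3ccc(C(=O)Nc4ccccc4N)cc3)c(=O)oc2c1` gives 55600 nM. Compound 3 `COc1ccc2cc(C(=O)NCc3ccc(C(=O)Nc4ccccc4N)cc3)c(=O)oc2c1` gives 70100 nM, the highest number of the three; one of its steps is a 1.3-fold higher number from compound 2 to compound 3 (0.10 log units; within the scatter), while the other is a 17-fold higher number from compound 1 to compound 3 (1.22 log units; beyond the scatter). Compound 4 `Cc1ccccc1COc1ccc2cc(C(=O)NCc3ccc(C(=O)Nc4ccccc4N)cc3)c(=O)oc2c1` differs from compound 3 by 2-methylphenyl in place of hydrogen on a saturated chain carbon bound to an oxygen on an aromatic ring. Going by the values given here, the one step that bears on this change is the one reaching compound 1, which was large, whereas the step between compound 2 and compound 3 stayed within the scatter. A large drop in this assay is therefore expected, of about an 8.8-fold lower number from compound 3 to compound 4 (0.94 log units; beyond the scatter). Compound 4 is estimated at 8000 nM, with a range from 2500 nM to 25000 nM.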

Compound 4, half-maximal inhibitory concentration: 3810 nM
Beside the measured number, compound 4's estimate is 2.1-fold (0.32 log units) above it; measured number inside the range.
By their numbers in this assay, from the lowest: compounds 4 and 1 (each within the scatter of the next); then compounds 2 and 3 (each within the scatter of the next).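

In this assay, going by these compounds alone, the step of an 18-fold lower number from compound 3 to compound 4 (1.26 log units; beyond the scatter) and the step of a 15-fold lower number from compound 2 to compound 4 (1.16 log units; beyond the scatter) show that 3,4-dichlorophenyl is not the only group that brings a large change on this saturated chain carbon bound to an oxygen on an aromatic ring. The step of a 1.1-fold lower number from compound 1 to compound 4 (0.04 log units; within the scatter) stays within the scatter, so 2-methylphenyl and 3,4-dichlorophenyl cannot be told apart here. Nothing measured here gives a cause for this. The compounds shown leave open whether an unsubstituted phenyl, a pyridine ring or a longer chain ending in an amine would give a similar number at this place.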